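The source may report more compounds than this note shows. Statements on the series, on what has been measured and on what is new or still open speak of the compounds shown alone.

Measured in a functional assay on COLO 205 cells (Homo sapiens) for cytotoxicity; on this read-out lower numbers stand for stronger inhibition and higher numbers for weaker inhibition:
- compound 1 `Cc1ccc(S(=O)(=O)N/C(=N\O)Nc2ccc(Cl)cc2)cc1`: 58 ug/mL
- compound 2 `O=S(=O)(N/C(=N\O)Nc1ccc(Cl)cc1)c1cc2ccccc2s1`: 80 ug/mL
- compound 3 `O=S(=O)(N/C(=N\O)Nc1ccc(Cl)cc1)c1cc(-c2ccsc2)no1`: 52 ug/mL

Compound 1 lies within the scatter of both compound 2 and compound 3, so the three cannot be ranked. Next is compound 4 `N#Cc1c(Cl)cccc1Oc1ccc(S(=O)(=O)N/C(=N\O)Nc2ccc(Cl)cc2)cc1`, which has 3-chloro-2-cyanophenoxy in place of methyl on an aromatic carbon, para to a large group: 3-chloro-2-cyanophenoxy in place of methyl on an aromatic carbon. Among the measured compounds shown here, no measured step isolates this change. Compound 2 at 80 ug/mL and compound 3 at 52 ug/mL carry other groups in that part of the molecule, yet both stay within the scatter of compound 1 at 58 ug/mL. In this assay, no step beyond the scatter is therefore expected, and the estimated change is a 1.2-fold lower number from compound 1 to compound 4 (0.08 log units; within the scatter). For compound 4 the expected value is 48 ug/mL, with an estimated range of 20 ug/mL to 100 ug/mL.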

Compound 4, half-maximal inhibitory concentration: 178 ug/mL
The estimate for compound 4 lay 3.7-fold (0.57 log units) below the measured number, and the stated range ends below it.
By their numbers in this assay, from the lowest: compounds 3, 1 and 2 (each within the scatter of the next); then compound 4.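

In this assay, among the compounds shown here, 3-chloro-2-cyanophenoxy in place of methyl on an aromatic carbon, para to a large group, gives a 3.1-fold higher number from compound 1 to compound 4 (0.49 log units; beyond the scatter), the first step beyond the scatter. This position therefore does not accept every replacement without a loss of inhibition. Nothing measured bears on the cause of this step. As far as these compounds go, it remains open whether the step follows from the added aromatic ring or from its chlorine and nitrile, and how an unsubstituted phenoxy, a methoxy or an amine would read at this position.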